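A few compounds are considered here, and "the series" means these few. Any claim that something is new, unique, unknown or untested is made for them only; others in the source may bear on it.

The series shares one core bearing a chloroacetamide on a pendant phenyl ring, and was tested in a functional assay on C6 cells (Rattus norvegicus) for cytotoxicity, read by MTT assay, with a stated time of 24 h; a higher number here means a weaker inhibitor, a lower number a stronger inhibitor. Compound 1 `Cc1ccc2oc(-c3ccc(NC(=O)CCl)cc3)nc2c1` gives 4040 nM in this assay. Compound 2 `Cc1cc(-c2nc3cc(Cl)ccc3o2)ccc1NC(=O)CCl` is reported in this assay only as a limit of the assay, > 100000 nM. Compound 2 thus sits at the limit of > 100000 nM in this assay, at which 1 of the 2 values shown sits, and offers no number to set against compound 1. From compound 2 the step to compound 3 `Cc1ccc2oc(-c3ccc(NC(=O)CCl)c(C)c3)nc2c1` is methyl in place of chloro on an aromatic carbon. For the measured compounds named here, no step between two compounds with measured numbers exists here, so the size of such a change cannot be read from a measured pair. Compound 1, which also carries methyl rather than chloro on its core, gives a number, which suggests the exchange should bring compound 3 back into measurable range; the step of an at least 5.0-fold lower number from compound 2 to compound 3 (0.69 log units; beyond the scatter) is expected. Compound 3 is therefore estimated at 20000 nM, with a range from 4000 nM to 150000 nM.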

Compound 3, half-maximal inhibitory concentration: 97600 nM
Compound 3: middle estimate off by 4.9-fold (0.69 log units), on the low side, and the stated range covers the measured number.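

Adding one methyl in place of hydrogen on the pendant phenyl ring gives, in this assay, a 24-fold higher number from compound 1 to compound 3 (1.38 log units; beyond the scatter), the first measured size of any change in this series. Compound 2 carries the same ring methyl and is reported only as a limit of the assay, not as a number: the limit of > 100000 nM in this assay, at which 1 of the 3 values shown sits. Methyl in place of chloro on the core gives an at least 1.0-fold lower number from compound 2 to compound 3 (0.01 log units; that floor lies within the scatter), so with the ring methyl present, this exchange shows no gain that can be told from the scatter.

The compounds shown leave open how chloro on the core would behave without the ring methyl. They also leave open whether the loss is particular to methyl, or whether a fluoro, a methoxy or an amine at that place on the pendant ring would give a similar number.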